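The source may report more compounds than this note shows. Statements on the series, on what has been measured and on what is new or still open speak of the compounds shown alone.

Within the data shown here, two esters of the shared core have numbers so far in a functional assay on the whole organism with Scenedesmus acutus as the target, with a stated time of 20 h; a lower number here means a stronger inhibitor, a higher number a weaker inhibitor. Compound 1 (`CC(C)OC(=O)c1cc(N2C(=O)C3=C(CCCC3)C2=O)c(F)cc1Cl`), the isopropyl ester, gives 89.1 nM. Compound 2 (`CC(C)COC(=O)c1cc(N2C(=O)C3=C(CCCC3)C2=O)c(F)cc1Cl`), the isobutyl ester, gives 407 nM, the higher of the two numbers and so the weaker inhibitor of the pair. Compound 3 (`CCC(C)OC(=O)c1cc(N2C(=O)C3=C(CCCC3)C2=O)c(F)cc1Cl`), not yet measured, rearranges the ester chain of compound 2: sec-butyl in place of isobutyl on an oxygen next to a carbonyl group. The atoms stay the same, and only the isobutoxycarbonyl becomes sec-butoxycarbonyl. Among the measured compounds shown here, one measured step bears on this, a 4.6-fold higher number from compound 1 to compound 2 (0.66 log units; beyond the scatter), a modest change beyond the scatter at the same oxygen. Sec-butyl is taken as the closer match to isopropyl, so part of that gap is expected to close, though a single step is thin support. The expected change is a 2.4-fold lower number from compound 2 to compound 3 (0.38 log units; beyond the scatter), toward a lower number. For compound 3 the estimated value in this assay is 170 nM, with an expected range of 70 nM to 400 nM.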

Compound 3, half-maximal inhibitory concentration: 74.1 nM
Compound 3: the middle estimate sits 2.3-fold (0.36 log units) above what was measured, within the range that was stated.
By their numbers in this assay, from the lowest: compounds 3 and 1 (each within the scatter of the next); then compound 2.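

In this assay the same atoms rearranged within the ester chain are enough to shift the result, with a 5.5-fold lower number from compound 2 to compound 3 (0.74 log units; beyond the scatter), so the earlier gap between isopropyl and isobutyl cannot be read as a matter of chain size alone. Methyl in place of hydrogen on the isopropyl chain gives a 1.2-fold lower number from compound 1 to compound 3 (0.08 log units; within the scatter), which places sec-butyl level with isopropyl and leaves compound 2, the isobutyl ester, as the only weaker inhibitor of the three. Nothing available here accounts for the difference between the isobutyl and sec-butyl esters.

Open, from the compounds shown here alone, is how tert-butyl, cyclopentyl or a longer chain would read on the same oxygen, and whether a carboxylic acid in place of the ester keeps any inhibition. These readings rest on three esters of the shared core in a single assay.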